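The source may hold more compounds than are shown below. What is called first, only, known or untested is meant among the compounds shown, and "the series" means these compounds.

Among the measured compounds shown here, compound 2 `Cc1cc(/C=C2\SC(=S)N(Cc3ccccc3)C2=O)c(C)n1-c1ccc(Cl)c(C(=O)O)c1` gives the lowest of the two numbers measured so far in an ADME assay on MT2 cells (Homo sapiens) for cytotoxicity, read by XTT assay, with a stated time of 4 days (on this read-out higher numbers stand for lower toxicity in this test and lower numbers for higher toxicity in this test), namely 68300 nM. Its nearest neighbour, compound 1 `Cc1cc(/C=C2\SC(=S)N(Cc3ccccc3)C2=O)c(C)n1-c1ccc(O)c(C(=O)O)c1`, gives 159000 nM in this assay, and the step of a 2.3-fold lower number from compound 1 to compound 2 (0.37 log units; beyond the scatter) shows how far that one swap moved the reading. Compound 3 `Cc1cc(/C=C2\SC(=S)N(Cc3ccccc3)C2=O)c(C)n1-c1cccc(C(=O)O)c1` is reached by hydrogen in place of chloro on an aromatic carbon. For the measured compounds named here, the only measured step that bears on this position is a 2.3-fold lower number from compound 1 to compound 2 (0.37 log units; beyond the scatter), a modest shift, so a change of similar or smaller size is expected, most likely back toward a higher number. Compound 3 is therefore expected to give about 100000 nM in this assay, between 40000 nM and 250000 nM. That expectation amounts to a step of a 1.5-fold higher number from compound 2 to compound 3 (0.17 log units; within the scatter).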

Compound 3, half-maximal cytotoxic concentration: 83400 nM
Beside the measured number, compound 3's estimate is 1.2-fold (0.08 log units) above it; the range from low to high includes it.
By their numbers in this assay, from the lowest: compounds 2, 3 and 1 (each within the scatter of the next, the first and the last beyond it).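

In this assay, hydrogen in place of chloro gives a 1.2-fold higher number from compound 2 to compound 3 (0.09 log units; within the scatter), and hydrogen in place of hydroxy gives a 1.9-fold lower number from compound 1 to compound 3 (0.28 log units; within the scatter). Compound 3 therefore cannot be told apart from either compound 1 or compound 2, even though those two differ from each other by more than the scatter, so having no substituent at this position gives no clear reference point. Nothing available here explains these readings. Going by these compounds, it remains open whether a fluoro, a methoxy or an amine at this position would move the number beyond the scatter.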